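Cytotoxicity notes on a curcuminoid enaminone series

The compounds below may be only part of what the source reports. "The series", "measured", "known", "first", "only" and "open" are said of these compounds alone.

The series has a shared core carrying two phenolic arms and an amine-bound methoxyalkyl chain. Compound 1 `COCCNC(=C\C(=O)/C=C/c1ccc(O)cc1)/C=C/c1ccc(O)cc1` and compound 3 `COCCCNC(=C\C(=O)/C=C/c1ccc(O)cc1)/C=C/c1ccc(O)cc1` carry the unsubstituted phenolic arms; compound 2 `COCCNC(=C\C(=O)/C=C/c1ccc(O)c(OC)c1)/C=C/c1ccc(O)c(OC)c1` and compound 4 `COCCCNC(=C\C(=O)/C=C/c1ccc(O)c(OC)c1)/C=C/c1ccc(O)c(OC)c1` carry the methoxylated arms. The difference between the two cores, from compound 1 to compound 2, is not broken down here.

In a toxicity assay on CHO-K1 cells (Cricetulus griseus) for cytotoxicity, read by MTT assay, with a stated time of 48 h (a higher number here means a weaker inhibitor, a lower number a stronger inhibitor), compound 1 gives 34900 nM, compound 3 gives 44900 nM and compound 2 gives 63000 nM. All three values sit within the scatter of one another, so no order among them can be read.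

One change is shared by two pairs. From compound 1 to compound 3 it is methoxymethyl in place of methoxy on a saturated chain carbon, two bonds along the chain from an amine nitrogen, and the step it made in this assay is a 1.3-fold higher number from compound 1 to compound 3 (0.11 log units; within the scatter). From compound 2 to compound 4 the same change reads (methoxymethyl in place of methoxy on a saturated chain carbon, two bonds along the chain from an amine nitrogen); the place description is identical in both pairs, so this is the same kind of change on the other core.

Compound 4 is not yet measured in this assay. Since the step from compound 1 to compound 3 stayed within the scatter, the expected step from compound 2 to compound 4 is a 1.3-fold higher number from compound 2 to compound 4 (0.10 log units; within the scatter), which rests on that earlier step being a 1.3-fold higher number from compound 1 to compound 3 (0.11 log units; within the scatter). Compound 4 is therefore estimated at 80000 nM in this assay, with an expected range from 35000 nM to 160000 nM.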

Compound 4, half-maximal inhibitory concentration: 53700 nM
Beside the measured number, compound 4's estimate is 1.5-fold (0.17 log units) above it; the measured number falls inside the stated range.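

In this assay the new step is a 1.2-fold lower number from compound 2 to compound 4 (0.07 log units; within the scatter), and set beside the earlier step on the other core it shows no difference that can be read: the same change on two cores in this assay, a 1.3-fold higher number (0.11 log units; within the scatter) from compound 1 to compound 3 and a 1.2-fold lower number (0.07 log units; within the scatter) from compound 2 to compound 4, 1.5-fold (0.18 log units) apart, within the scatter of two such steps

Going from (2-methoxyethyl)amino to (3-methoxypropyl)amino therefore leaves the number within the scatter on both the core of compound 1 and the core of compound 2, so in these two pairs the change carries from one core to the other as a step too small to read. This does not show that the change has no effect at all or that the two cores respond identically, and the differing signs of the two steps mean nothing at this size; two pairs also give no rule for any other core in the series.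

The compounds shown carry only these two methoxyalkyl chains on the amine nitrogen, so it stays open whether a longer chain, or a chain ending in a hydroxyl group, an amine or a carboxylic acid, would give a step beyond the scatter. Also open, from the compounds shown here alone, is whether the same chain change would stay this small in a cell line other than the one used here.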